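Swapping Pyridin-2-yl for Phenyl on Two Cores

A few compounds are considered here, and "the series" means these few. Any claim that something is new, unique, unknown or untested is made for them only; others in the source may bear on it.

Measured compounds:
compound 1, `O=C(NCc1ccccc1)c1cnc(-c2ccccn2)nc1`, in an assay on isolated protein for inhibition of Hematopoietic prostaglandin D synthase (Homo sapiens), read by fluorescence polarization (on this read-out lower numbers stand for stronger inhibition and higher numbers for weaker inhibition), compound 1 gives 7.14 nM
compound 2, `O=C(NCc1ccccc1)c1cnc(-c2ccccc2)nc1`, compound 2 gives 11.7 nM
compound 3, `c1ccc(-c2ncc(-c3cnc(-c4ccccn4)nc3)[nH]2)cc1`, compound 3 gives 1770 nM

Compounds 1 and 2 share one core and differ in a single place: phenyl in place of pyridin-2-yl on an aromatic carbon. This change gave a 1.6-fold higher number from compound 1 to compound 2 (0.21 log units; within the scatter), so the two values cannot be ordered with any confidence.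

Compound 3 rests on a different core. Its value in this assay lies far above those of compound 1 and compound 2, and both gaps are beyond the scatter. How the core of compound 3 differs from the core of compound 1 is not broken down here.

Compound 4, `c1ccc(-c2ncc(-c3cnc(-c4ccccc4)[nH]3)cn2)cc1`, has not yet been measured in this assay. It differs from compound 3 by phenyl in place of pyridin-2-yl on an aromatic carbon, which is the same change, at the same kind of place, that separates compound 1 from compound 2.

The step from compound 3 to compound 4 is therefore expected to be small, around a 1.5-fold higher number from compound 3 to compound 4 (0.17 log units; within the scatter), because the same change earlier gave a 1.6-fold higher number from compound 1 to compound 2 (0.21 log units; within the scatter). The expectation starts from compound 3, because compound 3 gives 1770 nM in this assay. On that basis compound 4 is estimated at 2600 nM in this assay, with a likely range from 1000 nM to 7000 nM.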

Compound 4, half-maximal inhibitory concentration: 8.88 nM
The estimate for compound 4 lay 290-fold (2.47 log units) above the measured number; the measured number lies below the stated range.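

In this assay, phenyl in place of pyridin-2-yl on an aromatic carbon, at the place between two ring nitrogen atoms, gave a 200-fold lower number from compound 3 to compound 4 (2.30 log units; beyond the scatter), a large step that shows this swap is not silent on every core in the series. The size of the step therefore did not carry over from one core to the other, and a result on one core was a poor guide to the result on the second: the same change on two cores in this assay, a 1.6-fold higher number (0.21 log units; within the scatter) from compound 1 to compound 2 and a 200-fold lower number (2.30 log units; beyond the scatter) from compound 3 to compound 4, 330-fold (2.51 log units) apart, beyond the scatter of two such steps. This rests on a single matched pair per core, so it shows that the effect of the swap depends on the core, but not why it does, nor how the swap would behave on any third core.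

The compounds shown leave open which part of the difference between the two cores sets the size of the step, and the core of compound 3 has not been compared with the core of compound 1 one change at a time. They also leave open whether another group in the same place, such as an amine or a methoxy group, would follow the small step or the large one.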